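A Fluorine Step on the Shared Core of Compound 1

The source may hold more compounds than are shown below. What is called first, only, known or untested is meant among the compounds shown, and "the series" means these compounds.

Measured so far:
- compound 1, `O=C1Nc2ccccc2C1(c1c[nH]c2ccc([N+](=O)[O-])cc12)c1c[nH]c2ccc([N+](=O)[O-])cc12`: 8000 nM
- compound 2, `O=C1Nc2ccc(F)cc2C1(c1c[nH]c2ccccc12)c1c[nH]c2ccccc12`: 12800 nM
- compound 3, `COc1cccc2[nH]cc(C3(c4c[nH]c5cccc(OC)c45)C(=O)Nc4ccc(F)cc43)c12`: 9400 nM

In a functional assay on DU-145 cells (Homo sapiens) for cytotoxicity, read by MTT assay, with a stated time of 48 h (on this read-out lower numbers stand for stronger inhibition and higher numbers for weaker inhibition), compound 1 gives 8000 nM. Compound 1 sits at one end of the three numbers, but its gaps to compound 3 and to compound 2 both fall within the usual scatter, so the three cannot be told apart on these data.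

Compound 4, `O=C1Nc2ccc(F)cc2C1(c1c[nH]c2ccc([N+](=O)[O-])cc12)c1c[nH]c2ccc([N+](=O)[O-])cc12`, has not yet been measured. It differs from compound 1 in one place: fluoro in place of hydrogen on an aromatic carbon. Compound 2 and compound 3, which carry fluoro at the same place on the shared core, give numbers in the same range as compound 1, though each also differs from compound 1 elsewhere, so no single-change comparison is available.

On this basis no step beyond the scatter is expected from compound 1 to compound 4, and the expected change is no change at the digits printed from compound 1 to compound 4 (within the scatter). Compound 4 is therefore estimated at 8000 nM in this assay, with a range from 4000 nM to 16000 nM.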

Compound 4, half-maximal inhibitory concentration: 7500 nM
Estimate against measurement, compound 4: 1.1-fold (0.03 log units) above, and the stated range covers the measured number.
By their numbers in this assay, from the lowest: compounds 4, 1, 3 and 2 (each within the scatter of the next).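

In this assay, fluoro in place of hydrogen gives a 1.1-fold lower number from compound 1 to compound 4 (0.03 log units; within the scatter), so the two compounds cannot be told apart. Compound 2 and compound 3 also carry fluoro at this aromatic carbon, but each differs from compound 1 elsewhere, so neither could show what fluoro alone does; this pair keeps everything else fixed and shows that, on this core, the swap produces no step beyond the scatter. Nothing in the available data offers an explanation for this result.

As far as these compounds go, what a chloro group, an amine or a carboxylic acid would do at this same carbon remains open. For the compounds shown here, it is also open whether fluoro would behave the same way on a core without the two nitro groups, as no single-change pair here tests that.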